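Swapping the Chlorophenyl for a Methoxyphenyl Group

The source may report more compounds than this note shows. Statements on the series, on what has been measured and on what is new or still open speak of the compounds shown alone.

Measured so far:
Compound 1, `Fc1ccc(-c2cn3ccnc3c(-c3ccc4ncn(C5CCCCC5)c4c3)n2)cc1`: 2.98%
Compound 2, `Clc1ccc(-c2cn3ccnc3c(-c3ccc4ncn(C5CCCCC5)c4c3)n2)cc1`: 10%

Of the compounds shown here, two have been tested in a functional assay on M14 cells (Homo sapiens) for inhibition, read by sulforhodamine B assay, with a stated time of 48 h, tested at 10 uM; on this read-out lower numbers stand for less inhibition and higher numbers for more inhibition at the one concentration tested (going by the name of the read-out). Compound 2 gives 10%, and compound 1 gives 2.98%; the step of a number 7 percentage points higher from compound 1 to compound 2 (within the scatter) lies within the usual scatter, so the two numbers cannot be told apart. Both numbers are low at the concentration tested, and compound 2 stands among the two with no separation from compound 1 that the scatter would allow.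

Compound 3 `COc1ccccc1-c1cn2ccnc2c(-c2ccc3ncn(C4CCCCC4)c3c2)n1` has not yet been measured in this assay. It differs from compound 2 in one place: 2-methoxyphenyl in place of 4-chlorophenyl on an aromatic carbon. Within the data shown here, no measured step involves a methoxy group. Among the measured compounds shown here, the only step available, a number 7 percentage points higher from compound 1 to compound 2 (within the scatter), exchanges one halogen for another and stayed within the scatter, so it gives no pointer to a step beyond the scatter in either direction. The expectation therefore rests on compound 2 alone, with a wide margin for the unknown. Compound 3 is expected to give 12%, in a range from 0% to 35%. This estimate corresponds to an expected step of a number 2 percentage points higher from compound 2 to compound 3 (within the scatter).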

Compound 3, a percentage reported as inhibition, at one concentration (the size of the read-out at that concentration, not a potency): 1.12%
For compound 3 the middle estimate is 10.9 percentage points above the measured one; low and high end bracket the measured number.
By their numbers in this assay, from the lowest: compounds 3, 1 and 2 (each within the scatter of the next).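

Compound 3 is the first compound shown in which this aromatic carbon of the shared core carries something other than a halogen-substituted phenyl ring. In this assay, 2-methoxyphenyl in place of 4-chlorophenyl gives a number 8.9 percentage points lower from compound 2 to compound 3 (within the scatter) and 2-methoxyphenyl in place of 4-fluorophenyl gives a number 1.9 percentage points lower from compound 1 to compound 3 (within the scatter) so neither step can be told from the scatter. The earlier pair showed only that one halogen could replace another without a readable change, whereas this result extends that to a change that removes the halogen and brings in an oxygen and a hydrogen-bond acceptor, and nothing available bears on why the number stays within the scatter.

All three compounds shown carry a substituted phenyl ring at this place, so it remains open whether any group here could move the number beyond the scatter. Going by these compounds, how an amine, a carboxylic acid or a longer chain would read at this place is unknown, as is whether the methoxy result depends on where that group sits on the phenyl ring.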